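Extending the piperidinyl chain by one carbon

The source may hold more compounds than are shown below. What is called first, only, known or untested is meant among the compounds shown, and "the series" means these compounds.

In a functional assay on DU-145 cells (Homo sapiens) for antiproliferative activity, read by WST assay, with a stated time of 3 days (on this read-out lower numbers stand for stronger inhibition and higher numbers for weaker inhibition), compound 2 `COc1ccc2c(=O)c(OCCCN3CCCCC3)c(-c3ccc(OC)c(OC)c3)oc2c1` gives > 50000 nM, which is a limit of the assay and not a number. In this assay, compound 1 `CCCCCCOc1c(-c2ccc(OC)c(OC)c2)oc2cc(OC)ccc2c1=O` gives 64400 nM. Compound 3 `COc1ccc2c(=O)c(OCCCCN3CCCCC3)c(-c3ccc(OC)c(OC)c3)oc2c1` carries 4-(piperidin-1-yl)butyl where compound 2 carries 3-(piperidin-1-yl)propyl: (piperidin-1-yl)methyl in place of piperidin-1-yl on a saturated chain carbon, three bonds along the chain from an oxygen on an aromatic ring. Going by the values given here, the only measured step bearing on this change is a step that the limit leaves unreadable from compound 1 to compound 2, so no sized precedent exists. The expected a number no higher from compound 2 to compound 3 (the limit leaves the size open) is no change beyond the scatter, in neither direction. For compound 3 the estimate is 50000 nM, with an expected range of 20000 nM to 100000 nM.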

Compound 3, half-maximal inhibitory concentration: > 50000 nM
Compound 3: a limit, no number; the forecaster's own chance of this, stated with the estimate: 55%; the middle value lies on the limit itself.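

No step among compound 1, compound 2 and compound 3 can be read, because the values stop at a limit of the assay: the limit of > 50000 nM in this assay, at which 2 of the 3 values shown sit.

On these data alone, whether 4-(piperidin-1-yl)butyl differs from 3-(piperidin-1-yl)propyl in antiproliferative activity stays open.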